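A few compounds are considered here, and "the series" means these few. Any claim that something is new, unique, unknown or untested is made for them only; others in the source may bear on it.

Measured so far in a physicochemical assay for solubility; a higher number here means a more soluble compound, a lower number a less soluble compound:
compound 1 `CN(C)CC(=O)N1CCC(NS(=O)(=O)c2cc(S(=O)(=O)c3ccccc3)ccc2C(F)(F)F)CC1` gives 100000 nM
compound 2 `CC(C)(C)OC(=O)N1CCC[C@@H]1C(=O)N1CCC(NS(=O)(=O)c2cc(S(=O)(=O)c3ccccc3)ccc2C(F)(F)F)CC1` gives 25000 nM
compound 3 `CC(C)C(=O)N1CCC[C@H]1C(=O)N1CCC(NS(=O)(=O)c2cc(S(=O)(=O)c3ccccc3)ccc2C(F)(F)F)CC1` gives 100000 nM

Compound 3 is level with compound 1, the two together holding the highest of the three numbers, with no change at the digits printed from compound 1 to compound 3 (within the scatter) as the step between them. Compound 4 `CC(C)(C)C(=O)N1CCC[C@H]1C(=O)N1CCC(NS(=O)(=O)c2cc(S(=O)(=O)c3ccccc3)ccc2C(F)(F)F)CC1` differs from compound 3 by isopropyl to tert-butyl, which is methyl in place of hydrogen on a saturated chain carbon bound to a carbonyl carbon and two saturated chain carbons as the counted change. Within the data shown here, no measured step makes this exact change. The closest evidence is the exchange of tert-butoxycarbonyl for isopropylcarbonyl, with a 4.0-fold higher number from compound 2 to compound 3 (0.60 log units; beyond the scatter) as its size, a modest step. The other modest step is a 4.0-fold lower number from compound 1 to compound 2 (0.60 log units; beyond the scatter) in the same read-out. Among the measured compounds shown here, compound 2 is the only measured compound with a tert-butyl-bearing group and gives 25000 nM, so a lower number is the likelier side. A step beyond the scatter is not expected, and the estimated change is a 1.4-fold lower number from compound 3 to compound 4 (0.15 log units; within the scatter) in this assay as a whole. For compound 4 the expected value is 70000 nM, with an estimated range of 25000 nM to 100000 nM for repeat measurements.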

Compound 4, solubility: 50000 nM
Beside the measured number, compound 4's estimate is 1.4-fold (0.15 log units) above it, within the range that was stated.
By their numbers in this assay, from the lowest: compounds 2, 4, 1 and 3 (each within the scatter of the next, the first and the last beyond it).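

In this assay, among these compounds, methyl in place of hydrogen on a saturated chain carbon bound to a carbonyl carbon and two saturated chain carbons gives a 2.0-fold lower number from compound 3 to compound 4 (0.30 log units; within the scatter), the first direct reading of isopropyl to tert-butyl at this position, and it does not leave the scatter. The steps of a 2.0-fold higher number from compound 2 to compound 4 (0.30 log units; within the scatter) and a 2.0-fold lower number from compound 1 to compound 4 (0.30 log units; within the scatter) also stay within the scatter, so compound 4 separates from none of the other three, even though compound 2 and compound 3 remain apart and compound 1 and compound 2 remain apart. No measured property in hand bears on these numbers.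

As far as these compounds go, whether a cyclohexyl group, an amine or a carboxylic acid on this carbonyl would move the number beyond the scatter stays open. From the compounds shown here alone, whether the same methyl gives a similar step on another chain also stays open.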